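Furan-2-yl Amide Thiourea Tested for Cytotoxicity

This account rests on a few compounds, and the source may have more. Where it says the series, first, only, none or still open, it means among the compounds named here.

Compound 3 `O=C(NC(=S)N1CCc2c(OCCCCCOc3ccc(Cl)cc3)cccc21)C1CCCC1` gives, in an ADME assay on Huh-7 cells (Homo sapiens) for cytotoxicity (on this read-out higher numbers stand for lower toxicity in this test and lower numbers for higher toxicity in this test), only a limit of the assay, > 50000 nM. Compound 1 `N#Cc1ccc(C(=O)NC(=S)N2CCc3c(OCCCCCOc4ccc(Cl)cc4)cccc32)cc1` also reaches only a limit, > 50000 nM. Compound 2 `Cc1ccc(C(=O)NC(=S)N2CCc3c(OCCCCCOc4ccc(Cl)cc4)cccc32)cc1` likewise gives a limit, > 50000 nM. All three values sit at the limit of > 50000 nM in this assay, at which 3 of the 3 values shown sit, so the steps among them cannot be read in size: a step that the two limits leave unreadable from compound 1 to compound 2, a step that the two limits leave unreadable from compound 1 to compound 3 and a step that the two limits leave unreadable from compound 2 to compound 3. Compound 4 `O=C(NC(=S)N1CCc2c(OCCCCCOc3ccc(Cl)cc3)cccc21)c1ccco1` differs from compound 3 by furan-2-yl in place of cyclopentyl on a carbonyl carbon. Within the data shown here, none of the measured steps offers a readable size that bears on this change; what the three measured compounds do show is that a 4-cyanophenyl, a 4-methylphenyl and a cyclopentyl on the carbonyl carbon all left the value at the limit. Compound 4 is therefore expected to stay near that limit as well, the expected step being a step that the limit leaves unreadable from compound 3 to compound 4. The estimate for compound 4 is 60000 nM, with a range from 25000 nM to 150000 nM.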

Compound 4, half-maximal cytotoxic concentration: 4620 nM
Beside the measured number, compound 4's estimate is 13-fold (1.11 log units) above it; measured number outside the range, below it.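

On the carbonyl carbon, the group can clearly shift the read-out in this assay: furan-2-yl in place of cyclopentyl gives an at least 10-fold lower number from compound 3 to compound 4 (1.03 log units; beyond the scatter), while the same group in place of the aromatic six-membered rings gives an at least 10-fold lower number from compound 2 to compound 4 (1.03 log units; beyond the scatter) and an at least 10-fold lower number from compound 1 to compound 4 (1.03 log units; beyond the scatter). Of the four groups shown at this place, only furan-2-yl, which alone brings a ring oxygen, takes the value off the limit, so higher toxicity in this test is not shared across the series. The steps among compound 1, compound 2 and compound 3 cannot be read, and the three steps to compound 4 are bounds rather than full sizes: the limit of > 50000 nM in this assay, at which 3 of the 4 values shown sit.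

The compounds shown leave open whether the ring oxygen or the aromatic five-membered ring matters more. A thiophen-2-yl or a furan-3-yl on this carbonyl carbon would begin to separate the two.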